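Furan-2-yl for Phenyl on Two Nucleoside Cores

This account rests on a few compounds, and the source may have more. Where it says the series, first, only, none or still open, it means among the compounds named here.

The measured compounds:
compound 1, `OC[C@H]1O[C@@H](n2cc(Cl)c3c(-c4ccccc4)ncnc32)[C@H](O)[C@@H]1O`: 44500 nM
compound 2, `OC[C@H]1O[C@@H](n2cc(Cl)c3c(-c4ccco4)ncnc32)[C@H](O)[C@@H]1O`: 37300 nM
compound 3, `CCCCCCCCCCCCCCCCCCOP(=O)(O)OC[C@H]1O[C@@H](n2ccc3c(-c4ccccc4)ncnc32)[C@H](O)[C@@H]1O`: > 50000 nM

In an ADME assay on BJ cells (Homo sapiens) for cytotoxicity, read by MTT assay, with a stated time of 72 h (on this read-out higher numbers stand for lower toxicity in this test and lower numbers for higher toxicity in this test), compound 1 gives 44500 nM, and compound 2 gives 37300 nM. The change between them is furan-2-yl in place of phenyl on an aromatic carbon, and it made a 1.2-fold lower number from compound 1 to compound 2 (0.08 log units; within the scatter). For compound 3 this assay reports only a limit, > 50000 nM. How the core of compound 3 differs from the core of compound 1 is not broken down here. Among the measured compounds shown here, compound 4 `CCCCCCCCCCCCCCCCCCOP(=O)(O)OC[C@H]1O[C@@H](n2ccc3c(-c4ccco4)ncnc32)[C@H](O)[C@@H]1O` is not yet measured; it differs from compound 3 by furan-2-yl in place of phenyl on an aromatic carbon, the same change as the one from compound 1 to compound 2, at a place described in the same words. Compound 4 is expected to show a step that the limit leaves unreadable from compound 3 to compound 4, because compound 3 sits at the limit of > 50000 nM in this assay, at which 1 of the 3 values shown sits, and the earlier step was within the scatter. The estimate for compound 4 is 55000 nM, with a range from 30000 nM to 110000 nM.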

Compound 4, half-maximal cytotoxic concentration: > 50000 nM
Compound 4: a limit, no number; the forecaster's own chance of this, stated with the estimate: 70%; the middle value lies beyond the limit too.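

No step can be read from compound 3 to compound 4, because both are reported only as a limit in this assay: the limit of > 50000 nM in this assay, at which 2 of the 4 values shown sit.

The compounds shown leave open whether furan-2-yl in place of phenyl shifts the read-out on the core of compound 3.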